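This account rests on a few compounds, and the source may have more. Where it says the series, first, only, none or still open, it means among the compounds named here.

The three measured compounds share one core and differ in the aryl group on it and in the amide tail. Compound 1 `Cn1cc(-c2ccccc2)c2cc(C(=O)NCc3ccc(C(=O)Nc4ccccc4N)cc3)[nH]c2c1=O` gives 230 nM in a functional assay on MV4-11 cells (Homo sapiens) for antiproliferative activity, read by CCK-8 assay, with a stated time of 72 h; on this read-out higher numbers stand for weaker inhibition and lower numbers for stronger inhibition. Compound 2 `CC(C)Oc1ccc(C(C)(C)O)cc1-c1cn(C)c(=O)c2[nH]c(C(=O)NCc3ccc(C(=O)NO)cc3)cc12` gives 350 nM in this assay, and compound 3 `Cn1cc(-c2ccccc2Oc2ccccc2)c2cc(C(=O)NCCCCCCC(=O)NO)[nH]c2c1=O` gives 180 nM in this assay. On these three numbers compound 1 stands second highest; its nearest neighbour is compound 3, whose value lies within the scatter of it, and the furthest is compound 2, whose value also lies within the scatter. The three compounds are therefore not told apart by these measurements, and no single change between two of them has been measured on its own.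

Compound 4 `Cc1ccccc1-c1cn(C)c(=O)c2[nH]c(C(=O)NCc3ccc(C(=O)Nc4ccccc4N)cc3)cc12` is compound 1 with one change: methyl in place of hydrogen on an aromatic carbon. Cut one bond further out, the phenyl of compound 1 becomes a 2-methylphenyl in compound 4. Within the data shown here, no measured pair shows what such a change does here, so the expectation can rest only on the values of compound 1 and the other two compounds. Compound 4 is expected to give 260 nM in this assay, between 110 nM and 650 nM. The step from a 1.1-fold higher number from compound 1 to compound 4 (0.05 log units; within the scatter) is expected to be no larger than the scatter, in either direction.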

Compound 4, half-maximal inhibitory concentration: 310 nM
Beside the measured number, compound 4's estimate is 1.2-fold (0.08 log units) below it; measured number inside the range.
By their numbers in this assay, from the lowest: compounds 3, 1, 4 and 2 (each within the scatter of the next).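

Among these compounds, replacing the phenyl of compound 1 with the 2-methylphenyl of compound 4 gives a 1.3-fold higher number from compound 1 to compound 4 (0.13 log units; within the scatter) in this assay, the first step in this set in which a single change can be read on its own. At this position, on an aromatic carbon ortho to a large group, a methyl in place of hydrogen therefore leaves the antiproliferative read-out indistinguishable from that of the unsubstituted phenyl, at least with the amide tail that compound 1 and compound 4 share. No supporting data bear on how the methyl acts here, so the result stands as an observation without an explanation.

On these data alone, it remains open whether a group other than methyl in this place, such as a chlorine atom, a methoxy group, an amine or a carboxylic acid, would also stay within the scatter, or whether it would move the number clearly in either direction. As far as these compounds go, it is equally open whether a methyl on another carbon of this ring, or the same methyl combined with the amide tail of compound 2 or compound 3, would give a comparable result.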